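A few compounds are considered here, and "the series" means these few. Any claim that something is new, unique, unknown or untested is made for them only; others in the source may bear on it.

Measured in a functional assay on HEp-2 cells (Homo sapiens) for inhibition, read by MTT assay, with a stated time of 72 h; a higher number here means a weaker inhibitor, a lower number a stronger inhibitor:
- compound 1 `CCCO[C@@H]1C=CC(=O)[C@@H](CO)O1`: 13400 nM
- compound 2 `CCO[C@@H]1C=CC(=O)[C@@H](CO)O1`: 5800 nM
- compound 3 `COCCOCCOCCO[C@@H]1C=CC(=O)[C@@H](CO)O1`: 32100 nM

Compound 2, at 5800 nM, holds the lowest of these three numbers. Compound 4 `C#CCCO[C@@H]1C=CC(=O)[C@@H](CO)O1` differs from compound 2 by ethynyl in place of hydrogen on a saturated chain carbon, two bonds along the chain from an oxygen on a saturated carbon.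

For the measured compounds named here, only one measured step bears directly on this carbon: a 2.3-fold lower number from compound 1 to compound 2 (0.36 log units; beyond the scatter). This modest step replaces methyl with hydrogen, so read in reverse, it points to a higher number when the chain gains carbon there. Compound 3, at 32100 nM, also lies higher than compound 2, but it does not differ from compound 2 by a single change. Going by the values given here, no compound with ethynyl has been measured, so the size remains uncertain. A modest rise in this assay is therefore expected, similar in size to the measured step. The expected change is a 1.9-fold higher number from compound 2 to compound 4 (0.28 log units; within the scatter). Compound 4 is estimated at 11000 nM, with an expected range of 4500 nM to 26000 nM.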

Compound 4, half-maximal inhibitory concentration: 7100 nM
Beside the measured number, compound 4's estimate is 1.5-fold (0.19 log units) above it; measured number inside the range.
By their numbers in this assay, from the lowest: compounds 2, 4 and 1 (each within the scatter of the next, the first and the last beyond it); then compound 3.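

In this assay, ethynyl in place of hydrogen on this saturated chain carbon gives a 1.2-fold higher number from compound 2 to compound 4 (0.09 log units; within the scatter), so the change from ethyl to but-3-yn-1-yl leaves no measurable difference here. Ethynyl in place of methyl at the same carbon gives a 1.9-fold lower number from compound 1 to compound 4 (0.28 log units; within the scatter), also no measurable difference, even though the hydrogen and methyl compounds are separated by a 2.3-fold lower number from compound 1 to compound 2 (0.36 log units; beyond the scatter); the shift seen with methyl is therefore not a general result of extending the chain at this carbon, and compound 4 goes against that reading. No measured evidence accounts for this difference between methyl and ethynyl.

As far as these compounds go, whether an amine or a carboxylic acid on this carbon would also stay within the scatter of compound 2 remains open. So does the outcome for a longer chain ending in ethynyl.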